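The source may report more compounds than this note shows. Statements on the series, on what has been measured and on what is new or still open speak of the compounds shown alone.

In a functional assay on HT-29 cells (Homo sapiens) for antiproliferative activity, read by sulforhodamine B assay, with a stated time of 72 h (a higher number here means a weaker inhibitor, a lower number a stronger inhibitor), three compounds sharing one core have been measured so far. Compound 1 `CCCCCCCCc1ccc(CCC(CO)(CO)NC(=O)CCCCCCC)c2ccccc12`, which carries an octyl group on an aromatic carbon, gives 22000 nM. Compound 3 `CCCCCCCOc1ccc(CCC(CO)(CO)NC(=O)CCCCCCC)c2ccccc12`, with heptyloxy in place of that octyl, gives 18800 nM. The change amounts to a 1.2-fold lower number from compound 1 to compound 3 (0.07 log units; within the scatter), so compound 3 stands level with compound 1. Compound 2 `CC(=O)NC(CO)(CO)CCc1ccc(O)c2ccccc12` gives > 80000 nM, which is a limit of the assay and not a number. Going by the values given here, compound 2 differs from compound 3 in more than one place, so it offers no clean step.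

Compound 4 `CCCCCCCOc1ccc(CCC(CO)(CO)NC(=O)OCc2ccccc2)c2ccccc12` departs from compound 3 at the carbonyl: benzyloxy in place of heptyl on a carbonyl carbon. In words, benzyloxy stands in place of heptyl on a carbonyl carbon, turning heptylcarbonyl into benzyloxycarbonyl. Among the compounds with values here, no measured step touches this place. The only one available, a 1.2-fold lower number from compound 1 to compound 3 (0.07 log units; within the scatter), lies on an aromatic carbon and bears on the new change only indirectly. With compound 3 at 18800 nM as the sole anchor, no firm direction can be argued, and a shift beyond the scatter is not expected. The estimated move in this assay is a 1.1-fold higher number from compound 3 to compound 4 (0.03 log units; within the scatter), with wide uncertainty. For compound 4 the expected value is 20000 nM, with an estimated range of 8000 nM to 50000 nM.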

Compound 4, half-maximal inhibitory concentration: 60500 nM
Compound 4: middle estimate off by 3.0-fold (0.48 log units), on the low side; measured number above the stated range.
By their numbers in this assay, from the lowest: compounds 3 and 1 (each within the scatter of the next); then compound 4. At a limit, above all of these: compound 2.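

Going by these compounds alone, the carbonyl carbon is the first place where a single change moves the number beyond the scatter in this assay (a 3.2-fold higher number from compound 3 to compound 4 (0.51 log units; beyond the scatter)), so benzyloxy does not serve as an equal replacement for heptyl there. Within the data shown here, the one earlier step, on an aromatic carbon, stayed within the scatter (a 1.2-fold lower number from compound 1 to compound 3 (0.07 log units; within the scatter)), which makes the carbonyl carbon the more responsive of the two places, on the evidence of just these two steps. Compound 2 remains a limit of the assay and not a number, so it sets no measured point for the series: the limit of > 80000 nM in this assay, at which 1 of the 4 values shown sits.

The change brings in an oxygen and a six-membered aromatic ring together, so the step cannot say which of the two goes with the higher number; a heptyloxycarbonyl group or a phenylacetyl group at the same carbon would pull them apart. Also open, as far as these compounds go, is how the number would read with a shorter chain such as butyl on this carbonyl carbon, or with a free amine in place of the whole (heptylcarbonyl)amino group.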